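Compound 3 to compound 4: a hydroxypyrrolidine side chain

The compounds below may be only part of what the source reports. "The series", "measured", "known", "first", "only" and "open" are said of these compounds alone.

Values in an ADME assay on NCM460 cells (Homo sapiens) for cytotoxicity, read by CCK-8 assay, with a stated time of 48 h; a higher number here means a weaker inhibitor, a lower number a stronger inhibitor:
compound 1 `COc1ccc(/C=C\c2cc(OC)c(OC)c(OC)c2)cc1OCc1ccc(CNCCO)cc1`: 39000 nM
compound 2 `COc1ccc(/C=C\c2cc(OC)c(OC)c(OC)c2)cc1OCc1ccc(CN2CC[C@H](C(=O)O)C2)cc1`: > 50000 nM (a limit)
compound 3 `COc1ccc(/C=C\c2cc(OC)c(OC)c(OC)c2)cc1OCc1ccc(CO)cc1`: > 50000 nM (a limit)

Compound 3 has no number, only the limit > 50000 nM. Its place in the series is described by the limit of > 50000 nM in this assay, at which 2 of the 3 values shown sit. Compound 1 alone has a numerical value, 39000 nM.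

Compound 4 `COc1ccc(/C=C\c2cc(OC)c(OC)c(OC)c2)cc1OCc1ccc(CN2CC[C@H](O)C2)cc1` keeps the core of compound 3 and carries 3-hydroxypyrrolidin-1-yl in place of hydroxy on a saturated chain carbon bound to an aromatic carbon.

Two measured steps change the same place. The first is an at least 1.2-fold higher number from compound 1 to compound 3 (0.10 log units; that floor lies within the scatter), with hydroxy in place of (2-hydroxyethyl)amino. Its floor lies within the scatter. The second is a step that the two limits leave unreadable from compound 2 to compound 3, with hydroxy in place of 3-carboxypyrrolidin-1-yl, and its size cannot be read. an at least 1.2-fold higher number from compound 1 to compound 2 (0.10 log units; that floor lies within the scatter) compares the two nitrogen-bearing side chains and also has a floor within the scatter.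

These steps give no firm direction for the change in this assay. Among the measured compounds shown here, the only number available is that of compound 1 at 39000 nM, so a value close to it is expected. A result reported only as a limit remains quite possible. For the measured compounds named here, the expected change is an at least 1.1-fold lower number from compound 3 to compound 4 (0.07 log units; that floor lies within the scatter), and no step clearly beyond the scatter is expected. For compound 4 the estimate is 42000 nM, with an expected range of 22000 nM to 80000 nM.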

Compound 4, half-maximal inhibitory concentration: 51000 nM
Beside the measured number, compound 4's estimate is 1.2-fold (0.08 log units) below it, and the stated range covers the measured number.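

Notes on the side chain on a saturated chain carbon bound to an aromatic carbon, in this assay. Compound 4 shows that a ring-bearing nitrogen side chain with a free hydroxy, 3-hydroxypyrrolidin-1-yl, can give a numerical reading at this place, so the series now has a second number alongside that of compound 1. Set against the open-chain (2-hydroxyethyl)amino group, the five-membered non-aromatic ring gives a 1.3-fold higher number from compound 1 to compound 4 (0.12 log units; within the scatter), so compound 1 and compound 4 are not told apart in this assay and the added ring sets no direction. Compound 2 and compound 3 each carry only a limit, and the steps from them to compound 4 cannot be read: the limit of > 50000 nM in this assay, at which 2 of the 4 values shown sit.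

All four side chains leave the readings at the upper end of this assay, and no readable step lies beyond the scatter, so the series does not yet show whether this place can move the value at all. Open questions are whether an amine without a hydroxy, such as dimethylamino or morpholin-4-yl, or a longer chain between the nitrogen and the hydroxy, would give a value clearly apart from those of compound 1 and compound 4.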